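Pyrimidinyl in place of methoxyphenyl on the amide nitrogen

The source may report more compounds than this note shows. Statements on the series, on what has been measured and on what is new or still open speak of the compounds shown alone.

Of the compounds shown here, three have been measured in a functional assay on SK-N-SH cells (Homo sapiens) for inhibition, read by sulforhodamine B assay, with a stated time of 48 h; on this read-out lower numbers stand for stronger inhibition and higher numbers for weaker inhibition. Compound 1 `CO[C@@H]1CC=C2NN(c3ccc(C)cc3)C(=O)C[C@]2(C)O1` gives 25300 nM, compound 2 `CO[C@@H]1CC=C2NN(c3cc4ccccc4[nH]3)C(=O)C[C@]2(C)O1` gives 19500 nM, and compound 3 `COc1ccc(N2NC3=CC[C@@H](OC)O[C@@]3(c3ccccc3)CC2=O)cc1` gives 10400 nM. Compound 3 stands below compound 1 by a gap beyond the scatter, while its gap to compound 2 lies within the scatter, so no order between compounds 2 and 3 can be claimed.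

Compound 4 `CO[C@@H]1CC=C2NN(c3cncnc3)C(=O)C[C@]2(c2ccccc2)O1` carries the change (pyrimidin-5-yl in place of 4-methoxyphenyl on an amide-type nitrogen in a ring). Among the measured compounds shown here, no measured pair shows this change, so the step is not known. With all three numbers so close together, the step from compound 3 to compound 4 is expected to be a 1.4-fold higher number from compound 3 to compound 4 (0.16 log units; within the scatter), not beyond the scatter in either direction. Compound 4 is therefore estimated to give 15000 nM in this assay, within a range of 5000 nM to 45000 nM.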

Compound 4, half-maximal inhibitory concentration: 8200 nM
The estimate for compound 4 lay 1.8-fold (0.26 log units) above the measured number, within the range that was stated.
By their numbers in this assay, from the lowest: compounds 4, 3, 2 and 1 (each within the scatter of the next, the first and the last beyond it).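

In this assay, pyrimidin-5-yl in place of 4-methoxyphenyl gives the first step read at this amide-type nitrogen (a 1.3-fold lower number from compound 3 to compound 4 (0.10 log units; within the scatter)). With the phenyl group held on the shared core, a ring with 2 hetero atoms can thus replace the carbon-only ring without moving the number beyond the scatter. Nothing at hand explains this outcome.

On these data alone, it remains open whether an amine or a carboxylic acid on this aromatic ring would shift the number beyond the scatter. As far as these compounds go, a saturated piperidine ring on this nitrogen also remains untested here.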